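Replacing a dimethylamide with a cyclic amine-bearing amide

The source may report more compounds than this note shows. Statements on the series, on what has been measured and on what is new or still open speak of the compounds shown alone.

Of the compounds shown here, three sharing one core have been measured in an assay for inhibition of 6-phosphofructo-2-kinase/fructose-2,6-bisphosphatase 3 (Homo sapiens), read by ADP-Glo, with a stated time of 2 h; a lower number here means a stronger inhibitor, a higher number a weaker inhibitor. Compound 1 `Cn1ccc2ccc(-c3cc(Nc4ccccc4S(=O)(=O)NCC4CCOCC4)cc4nccnc34)cc21` gives 26 nM. Compound 2 `CN(C)C(=O)c1ccncc1Nc1cc(-c2ccc3ccn(C)c3c2)c2nccnc2c1` gives 499 nM, the highest number of the three and therefore the weakest inhibitor of this small set. For the measured compounds named here, compound 3 `CN1CCC(NC(=O)c2ccncc2Nc2cc(-c3ccc4ccn(C)c4c3)c3nccnc3c2)CC1=O` gives 41 nM, and the only one-place step so far, a 12-fold lower number from compound 2 to compound 3 (1.09 log units; beyond the scatter), shows that exchanging the dimethylamino group on the carbonyl carbon for a larger ring-bearing amine lowers the number markedly.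

Compound 4 `CN1CCC(CNC(=O)c2ccncc2Nc2cc(-c3ccc4ccn(C)c4c3)c3nccnc3c2)C1` is built from compound 2 by a change of the same kind: ((1-methylpyrrolidin-3-yl)methyl)amino in place of dimethylamino on a carbonyl carbon. Going by the values given here, the entering group, like the one in compound 3, carries a ring and a hydrogen-bond donor where compound 2 has none. Because a 12-fold lower number from compound 2 to compound 3 (1.09 log units; beyond the scatter) was large, a drop of comparable direction is expected, though the ring here differs in size and position, so the expected step is held somewhat smaller: a 6.2-fold lower number from compound 2 to compound 4 (0.80 log units; beyond the scatter). Compound 4 is therefore expected to give about 80 nM, within a range from 30 nM to 200 nM.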

Compound 4, half-maximal inhibitory concentration: 74 nM
Estimate against measurement, compound 4: 1.1-fold (0.03 log units) above; the measured number falls inside the stated range.
By their numbers in this assay, from the lowest: compounds 1, 3 and 4 (each within the scatter of the next, the first and the last beyond it); then compound 2.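

A second ring-bearing amine on the carbonyl carbon also pays off: a 6.7-fold lower number from compound 2 to compound 4 (0.83 log units; beyond the scatter) is a clear gain, so the drop seen with compound 3 is not unique to one entering group. The a 1.8-fold higher number from compound 3 to compound 4 (0.26 log units; within the scatter) stays inside the usual scatter, so these two amides cannot be told apart even though their rings differ in size and only compound 3 carries the ring carbonyl. At this position, then, the 2-oxopiperidine and the (1-methylpyrrolidin-3-yl)methyl group serve about equally well.

On these data alone, both entering groups bring a ring, a ring nitrogen and an amide hydrogen together, so it remains open which of these matters; a plain methylamino or a cyclohexylamino group would separate them. Nothing measured here explains why these amides give lower numbers than compound 2.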